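A few compounds are considered here, and "the series" means these few. Any claim that something is new, unique, unknown or untested is made for them only; others in the source may bear on it.

Working notes on the series. In a functional assay on HCT-116 cells (Homo sapiens) for inhibition, read by MTT assay, with a stated time of 48 h (on this read-out lower numbers stand for stronger inhibition and higher numbers for weaker inhibition), compound 1 `C/C=C/C(=O)N(Cc1ccc(OC)c([N+](=O)[O-])c1)c1cc(OC)c(OC)c(OC)c1` gives 670 nM and compound 2 `C/C=C/C(=O)N(Cc1ccc(OC)c(N)c1)c1cc(OC)c(OC)c(OC)c1` gives 300 nM. Within the data shown here, compound 2 therefore holds the lower of the only two numbers available. Among the measured compounds shown here, the single measured step, a 2.2-fold lower number from compound 1 to compound 2 (0.35 log units; beyond the scatter), is amino in place of nitro on an aromatic carbon. It is modest but beyond the scatter.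

The next compound is compound 3 `C/C=C/C(=O)N(Cc1ccc(OC)c(Br)c1)c1cc(OC)c(OC)c(OC)c1`. The change is bromo in place of amino on an aromatic carbon, ortho to a methoxy group. For the measured compounds named here, the amino group that entered in the measured step now leaves from the same carbon, so that step is the only evidence bearing on this one. Going by the values given here, no bromo compound has been measured, which makes the transfer loose. A modest rise in this assay is expected, similar in size to a 2.2-fold lower number from compound 1 to compound 2 (0.35 log units; beyond the scatter), although a change beyond the scatter is not assured. The estimate amounts to an expected 1.7-fold higher number from compound 2 to compound 3 (0.22 log units; within the scatter). For compound 3 the estimated value is 500 nM, with an expected range of 150 nM to 1600 nM.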

Compound 3, half-maximal inhibitory concentration: 2800 nM
The estimate for compound 3 lay 5.6-fold (0.75 log units) below the measured number; the measured number lies above the stated range.
By their numbers in this assay, from the lowest: compound 2; then compound 1; then compound 3.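

In this assay this position, ortho to a methoxy group, is more sensitive to its substituent than the earlier step alone could show: the change from 3-amino-4-methoxyphenyl to 3-bromo-4-methoxyphenyl gives a 9.3-fold higher number from compound 2 to compound 3 (0.97 log units; beyond the scatter) and is far larger than the earlier 2.2-fold lower number from compound 1 to compound 2 (0.35 log units; beyond the scatter) for amino in place of nitro. Bromo in place of nitro also gives a 4.2-fold higher number from compound 1 to compound 3 (0.62 log units; beyond the scatter) and shows that the nitro compound does not mark the high end of the range, so the numbers rise from amino through nitro to bromo, with each step beyond the scatter and compound 3 the weakest of the three. Nothing at hand accounts for this order.

From the compounds shown here alone, whether the low number of compound 2 belongs to the amino group alone, or would also hold for a hydroxy group, a methylamino group or an acetamide on the same carbon, remains open. Also open, going by these compounds, is whether chloro or fluoro on that carbon would track bromo, which would show if the high number of compound 3 is particular to bromine or shared by other halogens.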